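Chain shortening from compound 2 to compound 3

This account rests on a few compounds, and the source may have more. Where it says the series, first, only, none or still open, it means among the compounds named here.

In an ADME assay on U2OS cells (Homo sapiens) for cytotoxicity (a lower number here means that less compound is tolerated, a higher number that more compound is tolerated), compound 1 (`CCCCCCCCc1ccc(C(=O)N/N=C/c2ccc([N+](=O)[O-])o2)cc1`) gives > 200000 nM as a limit and not a number. Compound 2 (`CCCCCCCCOc1ccc(C(=O)N/N=C/c2ccc([N+](=O)[O-])o2)cc1`) gives > 200000 nM in this assay as a limit too. Going by the values given here, compound 2 therefore stands without a number, and the one further value is also a limit, as the limit of > 200000 nM in this assay, at which 2 of the 2 values shown sit, records.

Compound 3 (`CCCCOc1ccc(C(=O)N/N=C/c2ccc([N+](=O)[O-])o2)cc1`) carries hydrogen in place of butyl on a saturated chain carbon, four bonds along the chain from an oxygen on an aromatic ring. Cut one bond further out, the same difference reads heptyl to propyl.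

Among the compounds with values here, the one measured step that bears on this is a step that the two limits leave unreadable from compound 1 to compound 2 and it gives no size to carry over. No change of chain length has been measured. No step beyond the scatter is therefore expected in this assay, in either direction, although a fall from the limit cannot be ruled out. The estimated step is a number no higher from compound 2 to compound 3 (the limit leaves the size open) and it is expected to stay small. For compound 3 the estimated value is 200000 nM with an expected range from 100000 nM to 300000 nM in this estimate.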

Compound 3, half-maximal cytotoxic concentration: 46600 nM
For compound 3 the middle estimate is 4.3-fold (0.63 log units) above the measured one; measured number below the stated range.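

In this assay, going by these compounds alone, the removal of butyl at this place on the chain gives the first readable step: an at least 4.2-fold lower number from compound 2 to compound 3 (0.63 log units; beyond the scatter). Measured against the octyl chain, the butoxy chain gives an at least 4.2-fold lower number from compound 1 to compound 3 (0.63 log units; beyond the scatter), so the butoxy chain of compound 3 is less tolerated by the cells than either eight-carbon chain, and chain length here does change the read-out, which the earlier pair could not show. Compound 1 and compound 2 remain limits and not numbers, so both new steps are minimum sizes and the step between these two cannot be read: the limit of > 200000 nM in this assay, at which 2 of the 3 values shown sit.

On these data alone, the true size of the shortening step stays open, as does its shape along the chain, since a single number at butoxy cannot tell a gradual trend from a sharp change somewhere between butoxy and octyloxy. As far as these compounds go, whether a hexyloxy or an ethoxy group falls in line with compound 3, and how a terminal amine or carboxylic acid on the butoxy chain would read in this assay, also remain open.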